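Hydroxy gives way to dimethylamino at the chain end

The compounds below may be only part of what the source reports. "The series", "measured", "known", "first", "only" and "open" are said of these compounds alone.

In a functional assay on MCF7 cells (Homo sapiens) for inhibition, read by sulforhodamine B assay (a lower number here means a stronger inhibitor of growth, a higher number a weaker inhibitor of growth), compound 1 `Cc1ccc2[nH]c(-c3ccc(-c4ccc(-c5ccc(N(C)C)cc5)cc4)cc3)nc2c1` gives 3130 nM, compound 2 `FC(F)(F)c1ccc(-c2ccc(-c3ccc(-c4nc5ccccc5[nH]4)cc3)cc2)cc1` gives 41400 nM and compound 3 `Oc1ccc(-c2ccc(-c3ccc(-c4nc5ccccc5[nH]4)cc3)cc2)cc1` gives 30500 nM. Compound 3 cannot be told apart from compound 2, and both numbers lie well above that of compound 1, a gap beyond the scatter.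

The next compound to be measured, compound 4 `CN(C)c1ccc(-c2ccc(-c3ccc(-c4nc5ccccc5[nH]4)cc3)cc2)cc1`, changes one end of compound 3: dimethylamino in place of hydroxy on an aromatic carbon. This places dimethylamino in place of hydroxy on an aromatic carbon, para to a large group. Within the data shown here, one measured step touches this position: a 1.4-fold lower number from compound 2 to compound 3 (0.13 log units; within the scatter), a change within the scatter. It involves trifluoromethyl and hydroxy only, so it says little about dimethylamino. Among the measured compounds shown here, the closer guide is compound 1, at 3130 nM, the only measured compound with the 4-(dimethylamino)phenyl end and the only one clearly lower in this assay. For the measured compounds named here, no measured step isolates that group, so this evidence remains indirect and the expectation carries a wide range.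

A move toward a lower number, beyond the scatter, is therefore expected, with an estimated step of a 5.1-fold lower number from compound 3 to compound 4 (0.71 log units; beyond the scatter). For compound 4 the estimated value is 6000 nM, with an expected range from 1800 nM to 20000 nM.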

Compound 4, concentration for 50% growth inhibition: 41200 nM
For compound 4 the middle estimate is 6.9-fold (0.84 log units) below the measured one; measured number above the stated range.
By their numbers in this assay, from the lowest: compound 1; then compounds 3, 4 and 2 (each within the scatter of the next).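

In this assay, dimethylamino in place of hydroxy on an aromatic carbon, para to a large group, gives a 1.4-fold higher number from compound 3 to compound 4 (0.13 log units; within the scatter) and so leaves the number within the scatter. Set against trifluoromethyl at the same place, dimethylamino gives a 1.0-fold lower number from compound 2 to compound 4 (0.00 log units; within the scatter) as well, so on this core the three end groups cannot be told apart. Among these compounds, the gap that set compound 1 apart now goes with the methyl on the core and not with the 4-(dimethylamino)phenyl end alone, for hydrogen in place of that methyl on an aromatic carbon gives a 13-fold higher number from compound 1 to compound 4 (1.12 log units; beyond the scatter) and is the only new step beyond the scatter, though nothing presented here accounts for it.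

The compounds shown leave open whether the methyl on the core would go with a lower number when the chain ends in hydroxy or trifluoromethyl, or only when it ends in dimethylamino. They also leave open what an ethyl or methoxy group on that carbon of the core, or a carboxylic acid at the chain end, would do in this assay.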